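The source may hold more compounds than are shown below. What is called first, only, known or untested is meant among the compounds shown, and "the series" means these compounds.

Among the compounds with values here, only two compounds built on a shared core have been measured so far in a functional assay on MCF7 cells (Homo sapiens) for antiproliferative activity, read by MTT assay, with a stated time of 72 h; a higher number here means a weaker inhibitor, a lower number a stronger inhibitor. There, compound 1 (`CCOC(=O)c1csc2nc(CN3CCN(Cc4ccccc4)CC3)c(-c3ccc(C)cc3)n12`) gives 29100 nM and compound 2 (`CCOC(=O)c1csc2nc(CN3CCN(C)CC3)c(-c3ccc(Br)cc3)n12`) gives 68500 nM as the higher of the two numbers, which makes compound 2 the weaker inhibitor by a gap beyond the usual scatter. Compound 3 (`CCOC(=O)c1csc2nc(CN3CCN(Cc4ccccc4)CC3)c(-c3ccc(Br)cc3)n12`) changes compound 2 in one place (phenyl in place of hydrogen on a saturated chain carbon bound to an amine nitrogen in a ring): phenyl in place of hydrogen on a saturated chain carbon bound to an amine nitrogen in a ring, so that methyl becomes benzyl. Compound 1 and compound 2 differ in more than one place, so no clean single-change comparison exists yet. Still, compound 1 carries the same benzyl group and gives 29100 nM in this assay, which points to a lower number. A modest drop is therefore expected, estimated as a 2.3-fold lower number from compound 2 to compound 3 (0.36 log units; beyond the scatter) and only slightly beyond the scatter. For compound 3 the estimated value is 30000 nM (expected range 12000 nM to 70000 nM) once it is measured.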

Compound 3, half-maximal inhibitory concentration: 51400 nM
Estimate against measurement, compound 3: 1.7-fold (0.23 log units) below; measured number inside the range.
By their numbers in this assay, from the lowest: compounds 1, 3 and 2 (each within the scatter of the next, the first and the last beyond it).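

With the bromo group held fixed, the change from methyl to benzyl, on a saturated chain carbon bound to an amine nitrogen in a ring, can now be read on its own in this assay (a 1.3-fold lower number from compound 2 to compound 3 (0.12 log units; within the scatter)), and adding this phenyl does not take the number outside the scatter. With benzyl held fixed, bromo in place of methyl on an aromatic carbon can also be read on its own (a 1.8-fold higher number from compound 1 to compound 3 (0.25 log units; within the scatter)), and this step likewise stays inside the scatter. No other data here bear on these two results.

From the compounds shown here alone, it remains open whether a longer alkyl chain or an acetyl group in place of benzyl would move the number beyond the scatter. Going by these compounds, what chloro or methoxy would do in place of bromo on the aromatic carbon is also open.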